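A few compounds are considered here, and "the series" means these few. Any claim that something is new, unique, unknown or untested is made for them only; others in the source may bear on it.

Three compounds have values in a physicochemical assay for lipophilicity, at pH 7.4 (on this read-out lower numbers stand for lower lipophilicity and higher numbers for higher lipophilicity), so far.

- compound 1 `O=C(NCc1cc(-c2ccc(C(F)(F)F)nc2)ncn1)[C@@H]1CCN1S(=O)(=O)c1ccc(F)cc1` gives 2.4
- compound 2 `O=C(NCc1cc(-c2ccc(C(F)(F)F)nc2)ncn1)[C@@H]1CCCN1S(=O)(=O)c1ccc(F)cc1` gives 2.7
- compound 3 `O=C(NCc1cc(-c2ccc(C(F)(F)F)nc2)ncn1)[C@@H]1CCCCN1S(=O)(=O)c1ccc(F)cc1` gives 3.4

Each number describes how a compound divides itself between an oily and a watery phase, so it can be compared directly across the set. In this assay compound 2 gives 2.7, which is within the usual scatter of compound 1 at 2.4. The gap to compound 3 at 3.4 is larger: that value is higher, and beyond the scatter.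

Compound 4 `C[C@H]1CC[C@@H](C(=O)NCc2cc(-c3ccc(C(F)(F)F)nc3)ncn2)N1S(=O)(=O)c1ccc(F)cc1` has not been measured yet. It differs from compound 2 in one place: methyl in place of hydrogen on a saturated ring carbon. In words, a methyl stands in place of a hydrogen on a saturated ring carbon of a five-membered non-aromatic ring with 1 nitrogen, next to the ring nitrogen.

Going by the values given here, no pair of measured compounds shows this exact change, so the data give no direct size for it. A modest rise in this assay is expected, a little beyond the scatter, and this step is estimated as a number 0.40 log units higher from compound 2 to compound 4 (beyond the scatter). That expectation leaves the new value close to the top of the set, where compound 3 gives 3.4. For compound 4 the expected value is 3.1, with an estimated range from 2.8 to 3.5.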

Compound 4, distribution coefficient: 2.9
The estimate for compound 4 lay 0.20 log units above the measured number, within the range that was stated.
By their numbers in this assay, from the lowest: compounds 1, 2 and 4 (each within the scatter of the next, the first and the last beyond it); then compound 3.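

In this assay, placing a methyl in place of hydrogen on a saturated ring carbon, next to the ring nitrogen, gives a step that lies within the scatter (a number 0.20 log units higher from compound 2 to compound 4 (within the scatter)), so repeated measurements of this kind could not reliably tell compound 2 and compound 4 apart. Going by these compounds alone, none of the earlier compounds carries a group at this place, so this pair gives the only direct reading of such a change: at this position, this extra carbon leaves the read-out with no clear difference. Within the data shown here, nothing in hand explains this outcome, and the single pair offers no way of telling why the step is so small.

The compounds shown leave open whether a longer chain such as ethyl, or a different group such as a hydroxyl or a single fluorine atom, would give a clear step at this same ring carbon. They also leave open whether a methyl with the opposite spatial arrangement at this carbon, or a methyl on another carbon of the same ring, would behave as this one does.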